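A tert-Butyl Variant Among Three Measured Modulators

This account rests on a few compounds, and the source may have more. Where it says the series, first, only, none or still open, it means among the compounds named here.

Compound 1, `CCc1nnc2c(C#N)c(N3CCC(c4ccccc4)CC3)ccn12`, gives 696 nM in a functional assay on CHO cells for positive allosteric modulation of metabotropic glutamate receptor 2 (Homo sapiens), read by GTPgammaS binding, with a stated time of 30 min; a higher number here means that more compound is needed for the effect, a lower number that less compound is needed.
Compound 2, `N#Cc1c(N2CCC(c3ccccc3)CC2)ccn2c(CC(F)(F)F)nnc12`, gives 56 nM in this assay.
Compound 3, `N#Cc1c(N2CCC(c3ccccc3)CC2)ccn2c(CC3CC3)nnc12`, gives 74 nM in this assay.

Compound 3 stands second highest of the three numbers. Its nearest neighbour is compound 2, separated by a 1.3-fold higher number from compound 2 to compound 3 (0.12 log units; within the scatter), within the scatter; compound 1 lies furthest away, as a 9.4-fold lower number from compound 1 to compound 3 (0.97 log units; beyond the scatter) shows. Compound 4, `CC(C)(C)c1nnc2c(C#N)c(N3CCC(c4ccccc4)CC3)ccn12`, has not been measured; relative to compound 3 the change is tert-butyl in place of cyclopropylmethyl on an aromatic carbon. Within the data shown here, the steps that bear on this position are a 12-fold lower number from compound 1 to compound 2 (1.09 log units; beyond the scatter) and a 9.4-fold lower number from compound 1 to compound 3 (0.97 log units; beyond the scatter), both going from methyl to a larger group, while the gap between the two larger groups, a 1.3-fold higher number from compound 2 to compound 3 (0.12 log units; within the scatter), is within the scatter. Tert-butyl itself has no measured parallel. The number for compound 4 is therefore expected to move little, a 1.4-fold higher number from compound 3 to compound 4 (0.13 log units; within the scatter). For compound 4 the estimate in this assay is 100 nM, with a range of 40 nM to 300 nM.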

Compound 4, half-maximal effective concentration: 1230 nM
The estimate for compound 4 lay 12-fold (1.09 log units) below the measured number; measured number above the stated range.
By their numbers in this assay, from the lowest: compounds 2 and 3 (each within the scatter of the next); then compounds 1 and 4 (each within the scatter of the next).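

At this position, on an aromatic carbon between two ring nitrogen atoms, the heavy-atom count does not settle the number in this assay: tert-butyl and cyclopropylmethyl both have 4 heavy atoms, yet the exchange gives a 17-fold higher number from compound 3 to compound 4 (1.22 log units; beyond the scatter) and so breaks the earlier trend. Tert-butyl also stands well apart from 2,2,2-trifluoroethyl, with a 22-fold higher number from compound 2 to compound 4 (1.34 log units; beyond the scatter), but it does not separate from ethyl, with a 1.8-fold higher number from compound 1 to compound 4 (0.25 log units; within the scatter), which is within the scatter. Nothing available explains this result. As far as these compounds go, whether isopropyl or a directly attached cyclopropyl would fall with compound 4 or with compound 3 remains open.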